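Swapping One Aryl Group for Thiophen-3-yl

A few compounds are considered here, and "the series" means these few. Any claim that something is new, unique, unknown or untested is made for them only; others in the source may bear on it.

Measured in a functional assay on MDA-MB-231 cells (Homo sapiens) for inhibition, read by MTT assay, with a stated time of 48 h; on this read-out lower numbers stand for stronger inhibition and higher numbers for weaker inhibition:
- compound 1 `COc1ccc(-c2nc3ccccn3c2Sc2ccccc2)cc1`: > 100000 nM
- compound 2 `Clc1ccc(Sc2c(-c3cccs3)nc3ccccn23)cc1`: 73100 nM

Going by the values given here, only two compounds have been tested so far, and both sit at the weak end of the scale. Compound 1 reads > 100000 nM, which is a limit of the assay and not a number. Its true value is therefore unknown, and any step starting from it is uncertain. Compound 2 does give a number, 73100 nM, and this is the only firm reference point.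

The next compound is compound 3 `c1ccc(Sc2c(-c3ccsc3)nc3ccccn23)cc1`, which has thiophen-3-yl in place of 4-methoxyphenyl on an aromatic carbon of the shared core: thiophen-3-yl in place of 4-methoxyphenyl on an aromatic carbon. The phenylsulfanyl group on the neighbouring ring atom stays.

Among the compounds with values here, no measured pair shows what a change like this does in this assay. Only a small move toward stronger inhibition is expected, and it may not exceed the scatter. The expected step is an at least 1.4-fold lower number from compound 1 to compound 3 (0.15 log units; that floor lies within the scatter). With compound 2 at 73100 nM as the guide, weak inhibition is expected again. For compound 3 the estimated value is 70000 nM, with an expected range from 30000 nM to 150000 nM.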

Compound 3, half-maximal inhibitory concentration: 62800 nM
Compound 3: middle estimate off by 1.1-fold (0.05 log units), on the high side; the measured number falls inside the stated range.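

With thiophen-3-yl in place of 4-methoxyphenyl on this aromatic carbon, and the phenylsulfanyl group on the neighbouring ring atom unchanged, compound 3 gives a true number in this assay, 62800 nM, so this position can hold a five-membered aromatic ring and still yield a measurable, though weak, reading. Going by these compounds alone, the change gives an at least 1.5-fold lower number from compound 1 to compound 3 (0.20 log units; that floor lies within the scatter), the first step in this set that speaks directly to this one position, since the two compounds differ nowhere else. That step is only a floor, and the real difference could be larger or could sit close to it, because compound 1 stands at a limit of the assay and not at a number: the limit of > 100000 nM in this assay, at which 1 of the 3 values shown sits.

On these data alone, what remains open is whether this shift belongs to thiophen-3-yl in particular or would appear with other replacements for 4-methoxyphenyl, as a single pair cannot separate the two. As far as these compounds go, it is also open whether any group on this aromatic carbon can move the reading clearly beyond the scatter, for example a ring carrying an amine or a carboxylic acid.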